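The source may hold more compounds than are shown below. What is called first, only, known or untested is meant among the compounds shown, and "the series" means these compounds.

Of the compounds shown here, three that share one core have been measured in a functional assay on B16-F10 cells (Mus musculus) for antiproliferative activity, read by MTT assay, with a stated time of 48 h; on this read-out higher numbers stand for weaker inhibition and lower numbers for stronger inhibition. Compound 1 `CCCCCCOc1ccc(C(=O)/C=C/c2c(/C=C/c3ccc(OC)cc3)cc(OC)cc2OC)cc1` gives 10.4 ug/mL, compound 2 `CCCC(C)Oc1ccc(C(=O)/C=C/c2c(/C=C/c3ccc(OC)cc3)cc(OC)cc2OC)cc1` gives 6.7 ug/mL, and compound 3 `COc1ccc(/C=C/c2cc(OC)cc(OC)c2/C=C/C(=O)c2ccc(Br)cc2)cc1` gives 6.5 ug/mL, the smallest of the three numbers, although its gaps to both others lie within the scatter. Compound 4 `COc1ccc(/C=C/c2cc(OC)cc(OC)c2/C=C/C(=O)c2ccc(-c3ccccc3)cc2)cc1` differs from compound 3 by phenyl in place of bromo on an aromatic carbon. Among the measured compounds shown here, the steps that bear on this change are a 1.6-fold lower number from compound 1 to compound 3 (0.20 log units; within the scatter) and a 1.0-fold lower number from compound 2 to compound 3 (0.01 log units; within the scatter), both exchanges on an aromatic carbon that moved the number only within the scatter. No step beyond the scatter is therefore expected here, and the estimated step is no change at the digits printed from compound 3 to compound 4 (within the scatter). Compound 4 is accordingly expected near 6.5 ug/mL, in a range from 3 ug/mL to 14 ug/mL.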

Compound 4, half-maximal inhibitory concentration: 10.6 ug/mL
The estimate for compound 4 lay 1.6-fold (0.21 log units) below the measured number; low and high end bracket the measured number.
By their numbers in this assay, from the lowest: compounds 3, 2, 1 and 4 (each within the scatter of the next).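

Even though phenyl brings a whole six-membered aromatic ring where bromo was a single atom, the step is only a 1.6-fold higher number from compound 3 to compound 4 (0.21 log units; within the scatter) and stays small. The same holds against the two ether groups, with a 1.6-fold higher number from compound 2 to compound 4 (0.20 log units; within the scatter) and a 1.0-fold higher number from compound 1 to compound 4 (0.01 log units; within the scatter) both printed as within the scatter, so bromo, 1-methylbutoxy, hexyloxy and phenyl cannot be told apart at this position. No measurement here offers a reason for this. Still open, as far as these compounds go, is whether an amine or a carboxylic acid at this position would also leave the number within the scatter.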